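Notes on the amide aryl group and the tail amine

This account rests on a few compounds, and the source may have more. Where it says the series, first, only, none or still open, it means among the compounds named here.

Measured compounds in a functional assay on A549 cells (Homo sapiens) for cytotoxicity, read by MTT assay, with a stated time of 72 h; on this read-out lower numbers stand for stronger inhibition and higher numbers for weaker inhibition:
- compound 1 `COc1cc2c(Oc3ccc(NC(=O)c4cc(-c5ccccc5)ccn4)cc3F)ccnc2cc1OCCCN1CCN(C)CC1` gives 340 nM
- compound 2 `COc1cc2c(Oc3ccc(NC(=O)c4cc(-c5ccc(C(F)(F)F)cc5)ccn4)cc3F)ccnc2cc1OCCCN1CCCCC1` gives 1640 nM
- compound 3 `COc1cc2c(Oc3ccc(NC(=O)c4cc(-c5ccc(C(F)(F)F)cc5)ccn4)cc3F)ccnc2cc1OCCCN1CCCC1` has "not determined" (no result reported) as its entry in this assay, so no number is available for it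

Compound 2 stands at the highest of the two numbers in this assay; its nearest neighbour is compound 1, whose lower number lies beyond the scatter. Compound 2 and compound 1 differ in two places, the group on the pendant phenyl and the amine at the end of the propoxy chain, so neither change can be assigned its own share of that gap.

Compound 4 `COc1cc2c(Oc3ccc(NC(=O)c4cc(-c5ccccc5)ccn4)cc3F)ccnc2cc1OCCCN1CCCCC1` is the direct single change from compound 2: hydrogen in place of trifluoromethyl on an aromatic carbon, in words hydrogen in place of trifluoromethyl on an aromatic carbon. The amine of compound 2 is kept, so the comparison isolates the aryl group. For the measured compounds named here, no measured pair shows this change alone; the only pointer is that compound 1, which also carries the unsubstituted phenyl, gives 340 nM. For compound 4 a step toward a lower number is expected, a 2.3-fold lower number from compound 2 to compound 4 (0.37 log units; beyond the scatter), likely beyond the scatter but of uncertain size. The expected value for compound 4 in this assay is 700 nM, within a range of 250 nM to 2000 nM.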

Compound 4, half-maximal inhibitory concentration: 1800 nM
Estimate against measurement, compound 4: 2.6-fold (0.41 log units) below, and the stated range covers the measured number.
By their numbers in this assay, from the lowest: compound 1; then compounds 2 and 4 (each within the scatter of the next).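

Read in this assay, hydrogen in place of trifluoromethyl on an aromatic carbon of the pendant ring gives a 1.1-fold higher number from compound 2 to compound 4 (0.04 log units; within the scatter), so with the piperidin-1-yl tail kept, 4-(trifluoromethyl)phenyl and phenyl are not separated at this position. For the compounds shown here, with the phenyl kept, piperidin-1-yl in place of 4-methylpiperazin-1-yl gives a 5.3-fold higher number from compound 1 to compound 4 (0.72 log units; beyond the scatter), which makes the amine at the end of the propoxy chain the only one of the two changes with a step beyond the scatter, although this rests on a single pair. Nothing in hand bears on why either step has the size it has.

On these data alone, each change is read only once, so it remains open whether trifluoromethyl and hydrogen also stay inseparable on a compound with the 4-methylpiperazin-1-yl tail. Also open, as far as these compounds go, is where a morpholin-4-yl or dimethylamino group at the end of the chain would fall relative to the two tails read here, and whether a nitrile or methoxy group in place of trifluoromethyl would leave the number within the scatter.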